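From 1-methyl-1H-indol-5-yl to 8-hydroxyquinolin-2-yl on a shared core

The source may report more compounds than this note shows. Statements on the series, on what has been measured and on what is new or still open speak of the compounds shown alone.

Values so far in a functional assay on K562 cells (Homo sapiens) for inhibition, read by trypan blue exclusion, with a stated time of 72 h (a higher number here means a weaker inhibitor, a lower number a stronger inhibitor), for two compounds:
Compound 1 `Cn1c(=O)c(S(=O)(=O)c2ccc(F)cc2F)cc2cnc(Nc3ccc4[nH]ncc4c3)nc21` gives 50000 nM
Compound 2 `Cn1ccc2cc(Nc3ncc4cc(S(=O)(=O)c5ccc(F)cc5F)c(=O)n(C)c4n3)ccc21` gives 750 nM

Compound 2 holds the lower of these two numbers, and its gap to compound 1 lies beyond the scatter. Among the measured compounds shown here, the one measured step bearing on what follows is a 67-fold lower number from compound 1 to compound 2 (1.82 log units; beyond the scatter), a large step that came with 1-methyl-1H-indol-5-yl in place of 1H-indazol-5-yl on a nitrogen on an aromatic ring.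

Compound 3 `Cn1c(=O)c(S(=O)(=O)c2ccc(F)cc2F)cc2cnc(Nc3ccc4cccc(O)c4n3)nc21` changes that same place, with 8-hydroxyquinolin-2-yl in place of 1-methyl-1H-indol-5-yl (8-hydroxyquinolin-2-yl in place of 1-methyl-1H-indol-5-yl on a nitrogen on an aromatic ring). A single step gives no rule for a new group, but it does show that this place can move the number a long way. For the measured compounds named here, a step beyond the scatter is therefore expected in this assay, more likely towards a higher number, as compound 2 at 750 nM is the lowest value so far. The estimate amounts to a 4.0-fold higher number from compound 2 to compound 3 (0.60 log units; beyond the scatter) as the expected step. For compound 3 the estimated value is 3000 nM, with an expected range from 400 nM to 30000 nM as its ends.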

Compound 3, half-maximal inhibitory concentration: 5000 nM
Compound 3: the middle estimate sits 1.7-fold (0.22 log units) below what was measured; the measured number falls inside the stated range.
By their numbers in this assay, from the lowest: compound 2; then compound 3; then compound 1.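

In this assay, moving to 8-hydroxyquinolin-2-yl on this nitrogen brought a 6.7-fold higher number from compound 2 to compound 3 (0.82 log units; beyond the scatter) and so left 1-methyl-1H-indol-5-yl with the lowest number of the three compounds. Set against 1H-indazol-5-yl, the same group gave a 10-fold lower number from compound 1 to compound 3 (1.00 log units; beyond the scatter) and thus placed compound 3 between the other two, which shows that this place gives more than a high and a low level: the three groups give three numbers, each beyond the scatter of the others. The entering group also brings a larger ring pair with a hydroxyl and a hydrogen-bond donor that 1-methyl-1H-indol-5-yl lacks, but no measurement here explains why the number changes with these groups.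

The compounds shown leave open whether the hydroxyl or the quinolin-2-yl frame accounts for the step, which a plain quinolin-2-yl or an 8-methoxyquinolin-2-yl group on the same core could separate. They also leave open how an amine or a carboxylic acid carried on 1-methyl-1H-indol-5-yl would fare at this place.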